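A single methyl on a weakly active compound

The source may report more compounds than this note shows. Statements on the series, on what has been measured and on what is new or still open speak of the compounds shown alone.

In a functional assay on Hs 683 cells (Homo sapiens) for inhibition, read by MTT assay, with a stated time of 72 h (on this read-out higher numbers stand for weaker inhibition of growth and lower numbers for stronger inhibition of growth), compound 1 (`CC(C)C(C)(C)[Si](C)(C)OC[C@H]1O[C@@H](n2ccc(=O)[nH]c2=O)[C@H](O)[C@@H]1O`) gives only a limit of the assay (> 100000 nM). Going by the values given here, compound 2 (`CC(C)[Si]1(C(C)C)OC[C@H]2O[C@@H](n3ccc(=O)[nH]c3=O)[C@H](O)[C@@H]2O[Si](C(C)C)(C(C)C)O1`) gives 83000 nM as the only true number so far, so it is the sole measured reference point. Compound 3 (`Cc1cn([C@@H]2O[C@@H]3CO[Si](C(C)C)(C(C)C)O[Si](C(C)C)(C(C)C)O[C@H]3[C@H]2O)c(=O)[nH]c1=O`) differs from compound 2 by methyl in place of hydrogen on an aromatic carbon. Among the compounds with values here, no measured step yet shows what so small a change does. The expected step of a 1.1-fold lower number from compound 2 to compound 3 (0.04 log units; within the scatter) is therefore none beyond the usual scatter, in either direction. Compound 3 is estimated at 75000 nM with an expected range from 35000 nM to 100000 nM for its result.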

Compound 3, concentration for 50% growth inhibition: 91000 nM
Compound 3: the middle estimate sits 1.2-fold (0.08 log units) below what was measured; measured number inside the range.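

In this assay, methyl in place of hydrogen on an aromatic carbon gives a 1.1-fold higher number from compound 2 to compound 3 (0.04 log units; within the scatter), so this first measured step at this position cannot be told apart from ordinary assay noise. Both compounds remain weak, and since any further weakening could be read only over a short stretch of the scale, the step says little about the position: the limit of > 100000 nM in this assay, at which 1 of the 3 values shown sits.

From the compounds shown here alone, whether an amine, a carboxylic acid or a longer chain at this position would move the number remains open. So does whether methyl would matter on a much more active compound.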